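A few compounds are considered here, and "the series" means these few. Any claim that something is new, unique, unknown or untested is made for them only; others in the source may bear on it.

Measured in a functional assay on BXPC-3 cells (Homo sapiens) for cytotoxicity, read by MTT assay, with a stated time of 72 h; a higher number here means a weaker inhibitor, a lower number a stronger inhibitor:
- compound 1 `Nc1ccc(-c2ccc(NC3=CC(=O)c4ncncc4C3=O)cc2)cc1`: 3500 nM
- compound 2 `O=C1C(Nc2cccc(B(O)O)c2)=CC(=O)c2ncncc21`: > 10000 nM (a limit of the assay, not a number)
- compound 3 `O=C1C=CC(=O)c2ncncc21`: 19400 nM

Only two of these results are actual numbers. Compound 1 has the lower of them, and compound 3 at 19400 nM lies higher by more than the usual scatter. That makes compound 1 the natural reference point.

Compound 4 `NS(=O)(=O)c1ccc(NC2=CC(=O)c3ncncc3C2=O)cc1` is built from compound 1 by a single change: sulfamoyl in place of 4-aminophenyl on an aromatic carbon. The rest of the molecule stays the same.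

Among the compounds with values here, no measured pair here differs in just one place, so the size of this step has to be judged from the values alone. A moderate step towards a higher number in this assay is expected, because compound 1 at 3500 nM already has the lowest number measured. The expected change is a 2.0-fold higher number from compound 1 to compound 4 (0.30 log units; within the scatter). For compound 4 the estimated value is 7000 nM, with an expected range of 2500 nM to 20000 nM.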

Compound 4, half-maximal inhibitory concentration: > 10000 nM
Compound 4 ended at the assay's limit; the forecaster's own chance of this, stated with the estimate: 25%; at least 1.4-fold (0.15 log units) between middle value and limit.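

Compound 4 gives > 10000 nM in this assay, and this is a limit of the assay, not a number. Even so, the limit supports a firm reading of the swap of 4-aminophenyl for sulfamoyl on this aromatic carbon, an at least 2.8-fold higher number from compound 1 to compound 4 (0.45 log units; beyond the scatter), which gives the first measured evidence that the group at this place matters and that 4-aminophenyl is the better of these two groups here. The true size of the loss cannot be given, because the measurement stops at a ceiling: the limit of > 10000 nM in this assay, at which 2 of the 4 values shown sit.

As far as these compounds go, it remains open whether compound 1 owes its lower number to the aromatic ring of 4-aminophenyl or to the amine on that ring, which an unsubstituted phenyl could help to separate. From the compounds shown here alone, what a carboxylic acid on this same aromatic carbon would give also stays unknown.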